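This account rests on a few compounds, and the source may have more. Where it says the series, first, only, none or still open, it means among the compounds named here.

Measured compounds:
compound 1 `CCn1cc(-c2nc3ccccc3[nH]2)c(=O)c2cc(F)c(N3CCNC(C)C3)c(F)c21`: 30200 nM
compound 2 `CCn1cc(-c2nc3ccccc3o2)c(=O)c2cc(F)c(N3CCNC(C)C3)c(F)c21`: 5700 nM

In a functional assay on Bel-7402 cells (Homo sapiens) for cytotoxicity, read by MTT assay, with a stated time of 48 h (on this read-out higher numbers stand for weaker inhibition and lower numbers for stronger inhibition), compound 2 gives 5700 nM, the lower of the two numbers and so the stronger inhibition. The next compound, compound 3 `CCn1cc(-c2nc3ccc([N+](=O)[O-])cc3o2)c(=O)c2cc(F)c(N3CCNC(C)C3)c(F)c21`, keeps the structure of compound 2 except for one change: nitro in place of hydrogen on an aromatic carbon. Going by the values given here, only one measured step bears on this, and only indirectly: a 5.3-fold lower number from compound 1 to compound 2 (0.72 log units; beyond the scatter), which came with 1,3-benzoxazol-2-yl in place of 1H-benzimidazol-2-yl on an aromatic carbon. Among the compounds with values here, no measured compound carries a nitro, so the direction is uncertain. A modest step towards a slightly lower number in this assay is expected, possibly none beyond the scatter. The expected change is a 1.4-fold lower number from compound 2 to compound 3 (0.15 log units; within the scatter). For compound 3 the estimated value is 4000 nM, with an expected range from 1200 nM to 14000 nM.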

Compound 3, half-maximal inhibitory concentration: 200 nM
Estimate against measurement, compound 3: 20-fold (1.30 log units) above; the whole stated range lies above it.
By their numbers in this assay, from the lowest: compound 3; then compound 2; then compound 1.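

Placing a substituent on the six-membered aromatic ring of carbon only, in the fused system of two rings, has a large effect in this assay: nitro in place of hydrogen gives a 29-fold lower number from compound 2 to compound 3 (1.45 log units; beyond the scatter) on this read-out. The earlier compounds shown here varied only the 1H-benzimidazol-2-yl and 1,3-benzoxazol-2-yl groups, and that exchange gave the smaller 5.3-fold lower number from compound 1 to compound 2 (0.72 log units; beyond the scatter). This carbon, which carried only hydrogen in those compounds, thus proves a sensitive place for change, though no measurement shown here accounts for the size of the step.

It remains open whether this step is specific to nitro, as neither an amine, a methoxy group nor a chlorine atom on this carbon is among the compounds shown. Also open, on these data alone, is whether nitro would have a similar effect on the 1H-benzimidazol-2-yl group of compound 1.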